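The compounds below may be only part of what the source reports. "The series", "measured", "known", "first", "only" and "open" are said of these compounds alone.

Measured compounds and their values in an ADME assay on BV-2 cells (Mus musculus) for cytotoxicity, with a stated time of 24 h, tested at 10 uM; a higher number here means a weaker effect of the compound at the concentration tested, a lower number a stronger effect:

- compound 1, `COc1ccccc1S(=O)(=O)/C=C/c1ncccc1F`: 100%
- compound 2, `COc1ccccc1S(=O)(=O)/C=C/c1ncccc1Cl`: 100%
- compound 3, `COc1cccc(S(=O)(=O)/C=C/c2ncccc2F)c1`: 100%

All three compounds share the same arrangement: an aromatic ring carrying a methoxy group, a sulfonyl group, a double bond, and a second six-membered aromatic ring with one nitrogen that bears a halogen. Compound 1 and compound 2 differ in only one place, (chloro in place of fluoro on an aromatic carbon), and this single exchange gave no change at the digits printed from compound 1 to compound 2 (within the scatter), so in this assay the two compounds cannot be told apart.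

Compound 3 has the same atoms as compound 1 joined differently; the difference between the two cores is not broken down here. In this assay compound 3 sits level with compound 1 and compound 2.

Compound 4, `COc1cccc(S(=O)(=O)/C=C/c2ncccc2Cl)c1`, has not yet been measured. Within the data shown here, it differs from compound 3 by chloro in place of fluoro on an aromatic carbon, which is the same change as the one from compound 1 to compound 2, made at a place described in the same words. The step from compound 3 to compound 4 is therefore expected to be no change at the digits printed from compound 3 to compound 4 (within the scatter), because the same change gave no change at the digits printed from compound 1 to compound 2 (within the scatter) and because compound 3 already gives 100%. For compound 4 the expected value in this assay is estimated at 100%, with the likely range from 90% to 100%.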

Compound 4, a percentage reported as activity, at one concentration (the size of the read-out at that concentration, not a potency): 100%
For compound 4 middle estimate and measured number coincide at the digits printed; low and high end bracket the measured number.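

In this assay, putting chloro in place of fluoro on an aromatic carbon gave no change at the digits printed from compound 3 to compound 4 (within the scatter) and, set beside the earlier step, the exchange reads the same on both cores: the same change on two cores in this assay, no change at the digits printed (within the scatter) from compound 1 to compound 2 and no change at the digits printed (within the scatter) from compound 3 to compound 4, 0 percentage points apart, within the scatter of two such steps. So on the two cores shown, a medicinal chemist could carry this exchange across and expect the read-out to stay where it was, and here the two halogens cannot be told apart. This does not show that the exchange is without effect in general: all four compounds give the same reading, so there is no case of a core with a lower reading in this assay on which to test it, and nothing here speaks to other concentrations, other cells or other read-outs.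

The compounds shown carry only fluoro or chloro at this place, so it stays open whether a different group there, such as an amine or a nitrile, would move the reading. All four also keep the methoxy group and the sulfonyl group, which leaves open what a carboxylic acid in place of the methoxy group, or a carbonyl in place of the sulfonyl group, would do.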